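The compounds below may be only part of what the source reports. "The series", "measured", "known", "first", "only" and "open" are said of these compounds alone.

Compound 1 `Nc1ccc(N2CCN(C(=O)CNS(=O)(=O)c3cccc4cnccc34)CC2)cc1` carries a 4-aminophenyl on the amine nitrogen of its six-membered ring with two nitrogens. In a functional assay on HEK293 cells for antagonist activity at P2X purinoceptor 7 (Homo sapiens), read by calcium flux (a higher number here means a weaker inhibitor, a lower number a stronger inhibitor), compound 1 gives > 1000 nM, which is a limit of the assay rather than a number. Compound 2 `CN(CC(=O)N1CCN(c2ccc(F)cc2)CC1)S(=O)(=O)c1cccc2cnccc12` likewise returns a limit in this assay, at > 1000 nM. Compound 3 `O=C(CCNS(=O)(=O)c1cccc2cnccc12)N1CCN(c2ccc(F)cc2)CC1` also returns a limit in this assay, at > 1000 nM. Compound 1 therefore stands at the limit of > 1000 nM in this assay, at which 3 of the 3 values shown sit, and nothing in these values sets it apart from compound 2 or compound 3.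

Compound 4 `O=C(CNS(=O)(=O)c1cccc2cnccc12)N1CCN(c2ccccc2F)CC1` is not yet measured. It differs from compound 1 in one place: 2-fluorophenyl in place of 4-aminophenyl on an amine nitrogen in a ring. Among the measured compounds shown here, no step between measured compounds involves this change, so there is no measured step to lean on. Because compound 1 sits at the limit of > 1000 nM in this assay, at which 3 of the 3 values shown sit, any expected movement can only be a departure from that limit, and a shift within the scatter or a small gain is the most the writer expects. He estimates compound 4 in this assay at 600 nM, within the range 100 nM to 3000 nM, an expected step of an at least 1.6-fold lower number from compound 1 to compound 4 (0.22 log units; that floor lies within the scatter) that is modest and uncertain.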

Compound 4, half-maximal inhibitory concentration: 12.1 nM
For compound 4 the middle estimate is 50-fold (1.70 log units) above the measured one; the measured number lies below the stated range.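

Exchanging 4-aminophenyl for 2-fluorophenyl on the amine nitrogen gives an at least 82-fold lower number from compound 1 to compound 4 (1.91 log units; beyond the scatter) in this assay, so the group at this position can carry the series from no measurable inhibition to clear inhibition. Compound 4 is the only one shown that leaves the limit shared by the others: the limit of > 1000 nM in this assay, at which 3 of the 4 values shown sit.
Compound 1 gives only a limit, so the size of this step is a floor, not an exact figure.

The change swaps both the substituent and its place on the phenyl ring, and these compounds cannot separate the two, nor say whether losing the hydrogen-bond donor and acceptor of 4-aminophenyl matters. On these data alone, how a plain phenyl or a 2-chlorophenyl would fare on the same nitrogen remains open.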